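Butoxy in Place of Fluoro: Expected Effect on Transporter Inhibition

This account rests on a few compounds, and the source may have more. Where it says the series, first, only, none or still open, it means among the compounds named here.

Of the compounds shown here, two have so far been tested in a functional assay on striatum for inhibition of sodium-dependent dopamine transporter (Rattus norvegicus); a lower number here means a stronger inhibitor, a higher number a weaker inhibitor. Compound 1 `CCCCOc1ccc([C@@H]2CC[C@@H](NC)c3ccccc32)cc1` gives 6800 nM in this assay. Compound 2 `CN[C@H]1CC[C@@H](c2ccc(F)cc2)c2ccccc21` gives 4700 nM in this assay. Compound 2 holds the lower of these two numbers, but its gap to compound 1 lies within the scatter of repeated measurements, so the two cannot be told apart on this evidence.

Compound 3 `CCCCOc1ccc([C@@H]2CC[C@H](NC)c3ccccc32)cc1` has not yet been measured. It differs from compound 2 in one place: butoxy in place of fluoro on an aromatic carbon. Going by the values given here, no pair of measured compounds shows the effect of this exchange on its own, so the expectation rests only on the two values in hand. Because compound 1, which also carries a butoxy group on its aromatic ring, gives 6800 nM, a number in the same region seems the most likely outcome. The step from compound 2 to compound 3 is expected to be a 1.3-fold higher number from compound 2 to compound 3 (0.11 log units; within the scatter), most likely not beyond the scatter. Compound 3 is therefore estimated at 6000 nM, with a plausible range from 2000 nM to 18000 nM.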

Compound 3, half-maximal inhibitory concentration: 12500 nM
For compound 3 the middle estimate is 2.1-fold (0.32 log units) below the measured one; the measured number falls inside the stated range.
By their numbers in this assay, from the lowest: compounds 2, 1 and 3 (each within the scatter of the next, the first and the last beyond it).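

In this assay, the exchange of fluoro for butoxy on an aromatic carbon, para to a large group, now has a measured size: a 2.7-fold higher number from compound 2 to compound 3 (0.42 log units; beyond the scatter). Going by these compounds alone, this is a modest step towards a weaker inhibitor, and it is the first change that can be read beyond the scatter, so this position does respond to the group placed on it. The result also gives a first look at the drawn configuration of a saturated ring carbon, where the step is a 1.8-fold higher number from compound 1 to compound 3 (0.26 log units; within the scatter), so compounds 1 and 3 cannot be told apart and no effect of that stereocentre can be read from this pair, whose comparison rests on one point: the fact that compounds 1 and 3 differ only in the configuration as drawn

The compounds shown leave open whether the step follows the length of the chain, since a single pair cannot separate the butoxy chain from its oxygen, and a methoxy group, a hexyloxy chain or a plain butyl chain at the same position would help to decide this. They also leave open how a hydroxyl group or an amine would fare at that carbon.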